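A few compounds are considered here, and "the series" means these few. Any claim that something is new, unique, unknown or untested is made for them only; others in the source may bear on it.

Measured compounds:
compound 1 `O=C1CCC(=O)N1C[C@H]1CN(c2ccc(-n3cc(-c4ccccn4)cn3)c(F)c2)C(=O)O1` — 1.58
compound 2 `O=C(OC[C@H]1CN(c2ccc(-n3cc(-c4ccccn4)cn3)c(F)c2)C(=O)O1)c1ccccc1` — 4.21
compound 3 `COC[C@H]1CN(c2ccc(-n3cc(-c4ccccn4)cn3)c(F)c2)C(=O)O1` — 2.18

In a physicochemical assay for lipophilicity, read by HPLC, measured as octanol-water partition (a higher number here means a more lipophilic compound, a lower number a more polar compound), compound 1 stands lowest of the three; compound 3 lies a number 0.60 log units higher from compound 1 to compound 3 (beyond the scatter) and compound 2 lies a number 2.63 log units higher from compound 1 to compound 2 (beyond the scatter). Compound 4 `O=C1O[C@@H](Cn2ccnn2)CN1c1ccc(-n2cc(-c3ccccn3)cn2)c(F)c1` differs from compound 1 by 1H-1,2,3-triazol-1-yl in place of 2,5-dioxopyrrolidin-1-yl on a saturated chain carbon bound to a saturated ring carbon. Both measured steps from compound 1 replace the same group at the same place and raised this assay, the benzoyloxy step by a large margin and the methoxy step by a modest one. The triazole that enters is a small aromatic ring carrying three acceptors, so a step nearer the modest one, upward but close to the scatter, is expected: a number 0.27 log units higher from compound 1 to compound 4 (within the scatter). Compound 4 is therefore estimated at 1.85, within 1.35 to 2.4.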

Compound 4, partition coefficient: 2
The estimate for compound 4 lay 0.15 log units below the measured number, and the stated range covers the measured number.
By their numbers in this assay, from the lowest: compound 1; then compounds 4 and 3 (each within the scatter of the next); then compound 2.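

In this assay, 1H-1,2,3-triazol-1-yl becomes a third replacement for 2,5-dioxopyrrolidin-1-yl at this place that raises the number (a number 0.42 log units higher from compound 1 to compound 4 (beyond the scatter)), so all three replacements shown go the same way. The triazole and methoxy cannot be told apart here (a number 0.18 log units lower from compound 3 to compound 4 (within the scatter)), whereas benzoyloxy stands well clear of the triazole (a number 2.21 log units lower from compound 2 to compound 4 (beyond the scatter)). Nothing available explains why these groups fall as they do. Still open, from the compounds shown here alone, is how an amine or a carboxylic acid would read on this saturated chain carbon. Going by these compounds, a longer chain carrying the triazole also remains open.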